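Swapping naphthyl for methoxyphenyl on the ketone

The compounds below may be only part of what the source reports. "The series", "measured", "known", "first", "only" and "open" are said of these compounds alone.

Compound 1: `COc1cc(-c2nnc3n2NC(c2ccco2)C(C(=O)c2ccccc2C)S3)cc(OC)c1OC`; in a functional assay on PC-3 cells (Homo sapiens) for cytotoxicity, read by MTT assay, with a stated time of 48 h (a lower number here means a stronger inhibitor, a higher number a weaker inhibitor), compound 1 gives 88400 nM.
Compound 2: `COc1cc(C(=O)C2Sc3nnc(-c4cc(OC)c(OC)c(OC)c4)n3NC2c2ccco2)cc(OC)c1OC`; compound 2 gives 52200 nM.
Compound 3: `COc1cc(-c2nnc3n2NC(c2ccco2)C(C(=O)c2cccc4ccccc24)S3)cc(OC)c1OC`; compound 3 reaches only a limit of the assay, > 100000 nM.

Compound 3 therefore stands at the floor of what was measured: its value is one of the values sitting at the limit of > 100000 nM in this assay, at which 1 of the 3 values shown sits, and no number is known for it. The unmeasured compound 4 is `COc1ccc(C(=O)C2Sc3nnc(-c4cc(OC)c(OC)c(OC)c4)n3NC2c2ccco2)cc1`. It differs from compound 3 by 4-methoxyphenyl in place of naphthalen-1-yl on a carbonyl carbon.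

Among the measured compounds shown here, two measured steps touch the same position. One is an at least 1.1-fold higher number from compound 1 to compound 3 (0.05 log units; that floor lies within the scatter), the other at least 1.9-fold higher number from compound 2 to compound 3 (0.28 log units; that floor lies within the scatter). Both lead toward the limit, and neither floor clears the scatter. Compound 4 carries a single six-membered aromatic ring on the carbonyl carbon, as compound 1 and compound 2 do, so its number is expected to fall back into the region of those two, with the step of an at least 1.4-fold lower number from compound 3 to compound 4 (0.15 log units; that floor lies within the scatter) expected in the direction of a lower number but not surely beyond the scatter. Compound 4 is thus estimated at 70000 nM, within 35000 nM to 150000 nM.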

Compound 4, half-maximal inhibitory concentration: > 100000 nM
Compound 4 gave a limit, no number (the forecaster's own chance of this, stated with the estimate: 30%); middle value at least 1.4-fold (0.15 log units) away from the limit.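

In this assay compound 3 and compound 4 both end at a limit, so a single six-membered aromatic ring on the carbonyl carbon does not by itself return a readable number, which compound 1 and compound 2 alone could not show: the limit of > 100000 nM in this assay, at which 2 of the 4 values shown sit.

The change to 4-methoxyphenyl gives an at least 1.9-fold higher number from compound 2 to compound 4 (0.28 log units; that floor lies within the scatter) and an at least 1.1-fold higher number from compound 1 to compound 4 (0.05 log units; that floor lies within the scatter), so neither floor shows a change beyond the scatter. The step from compound 3 to compound 4 cannot be read, with a limit at both ends.

On these data alone, it remains open how far past the limit compound 3 and compound 4 lie. Also open, as far as these compounds go, is whether an amine or a carboxylic acid on the ring at the carbonyl carbon, or a butyl chain in place of that ring, would give a lower number than compound 2, at 52200 nM.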